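The source may report more compounds than this note shows. Statements on the series, on what has been measured and on what is new or still open speak of the compounds shown alone.

Series notes. Compound 1 `O=C1O[C@H]([C@@H](O)Cn2cc(-c3cccc(O)c3)nn2)C(OCc2ccccc2)=C1OCc1ccccc1`, compound 2 `COc1ccccc1-c1cn(C[C@H](O)[C@H]2OC(=O)C(OCc3ccccc3)=C2OCc2ccccc2)nn1` and compound 3 `COc1ccccc1-c1cn(C/C=C2\OC(=O)C(OCc3ccccc3)=C2OCc2ccccc2)nn1` have been measured in a functional assay on SW-620 cells (Homo sapiens) for antiproliferative activity, read by MTT assay, with a stated time of 72 h; a higher number here means a weaker inhibitor, a lower number a stronger inhibitor. In this assay compound 1 gives > 100000 nM, which is a limit of the assay. Compound 2 gives > 100000 nM, also a limit. Compound 3 gives > 100000 nM, again a limit. The change from compound 2 to compound 1 is 3-hydroxyphenyl in place of 2-methoxyphenyl on an aromatic carbon, and its step that the two limits leave unreadable from compound 2 to compound 1 cannot be read because of the limit of > 100000 nM in this assay, at which 3 of the 3 values shown sit. The cores of compound 2 and compound 3 differ, but that difference is not broken down here. Compound 4 `O=C1O/C(=C\Cn2cc(-c3cccc(O)c3)nn2)C(OCc2ccccc2)=C1OCc1ccccc1` is not yet measured; it arises from compound 3 by the same change, (3-hydroxyphenyl in place of 2-methoxyphenyl on an aromatic carbon). Compound 4 is expected to sit at the limit as well, with an estimated step that the limit leaves unreadable from compound 3 to compound 4, since compound 3 shows only > 100000 nM. The estimate for compound 4 is 150000 nM, between 50000 nM and 500000 nM.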

Compound 4, half-maximal inhibitory concentration: 69800 nM
For compound 4 the middle estimate is 2.1-fold (0.33 log units) above the measured one; the measured number falls inside the stated range.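

In this assay the change to 3-hydroxyphenyl from 2-methoxyphenyl on the core of compound 3 gives an at least 1.4-fold lower number from compound 3 to compound 4 (0.15 log units; that floor lies within the scatter) and so sets only a floor, which does not establish a change beyond the scatter. Going by these compounds, compound 3 has only a limit of the assay, so the true size of this step stays unknown. The same change on the core of compound 2 cannot be read, so nothing shows whether it carries from one core to the other: the limit of > 100000 nM in this assay, at which 3 of the 4 values shown sit.

Still open, on these data alone, is whether the hydroxyl or its place on the phenyl ring accounts for the number of compound 4, which 2-hydroxyphenyl and 3-methoxyphenyl would separate. Also open, as far as these compounds go, is how 3-aminophenyl or 3-carboxyphenyl would read in this assay on either core.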